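Adding a Third Methoxy to the Ketone-Side Ring

A few compounds are considered here, and "the series" means these few. Any claim that something is new, unique, unknown or untested is made for them only; others in the source may bear on it.

Three compounds sharing one core have numbers in a functional assay on SF-268 cells (Homo sapiens) for inhibition, read by sulforhodamine B assay, with a stated time of 48 h; on this read-out lower numbers stand for stronger inhibition of growth and higher numbers for weaker inhibition of growth. Compound 1 `COc1cc(-c2cc(/C=C/C(=O)c3ccc(N)cc3)[nH]n2)cc(OC)c1OC` gives 3930 nM in this assay. Compound 2 `COc1ccc(C(=O)/C=C/c2cc(-c3cc(OC)c(OC)c(OC)c3)n[nH]2)cc1OC` gives 3960 nM in this assay. For compound 3 `COc1cc(-c2cc(/C=C/C(=O)c3ccc(F)c(F)c3)[nH]n2)cc(OC)c1OC` this assay reports only a limit, > 100000 nM (the limit of > 100000 nM in this assay, at which 1 of the 3 values shown sits). Among the two actual numbers compound 2 carries the higher one, though its nearest neighbour, compound 1, sits within the scatter of it.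

The steps between the measured compounds all change the ring on the carbonyl carbon: a 1.0-fold higher number from compound 1 to compound 2 (0.00 log units; within the scatter), whereas an at least 25-fold higher number from compound 1 to compound 3 (1.40 log units; beyond the scatter) and an at least 25-fold higher number from compound 2 to compound 3 (1.40 log units; beyond the scatter).

Compound 4 `COc1cc(C(=O)/C=C/c2cc(-c3cc(OC)c(OC)c(OC)c3)n[nH]2)cc(OC)c1OC` differs from compound 2 by methoxy in place of hydrogen on an aromatic carbon, the entering group sitting on a six-membered aromatic ring of carbon only, ortho to a methoxy group and meta to a methoxy group and to a large group. Within the data shown here, no measured step adds a methoxy to this ring; the nearest guide is the step from compound 1 to compound 2, where exchanging one ring for another on the carbonyl carbon stayed within the scatter. Compound 4 is therefore expected to land near compound 2, with a 1.1-fold higher number from compound 2 to compound 4 (0.06 log units; within the scatter), and no step beyond the scatter. The estimate for compound 4 in this assay is 4500 nM, between 1500 nM and 15000 nM.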

Compound 4, concentration for total growth inhibition: 4580 nM
Compound 4: the middle estimate sits 1.0-fold (0.01 log units) below what was measured, within the range that was stated.
By their numbers in this assay, from the lowest: compounds 1, 2 and 4 (each within the scatter of the next). At a limit, above all of these: compound 3.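

In this assay, methoxy in place of hydrogen on an aromatic carbon, ortho to a methoxy group and meta to a large group and to a second methoxy group, gives a 1.2-fold higher number from compound 2 to compound 4 (0.06 log units; within the scatter) and so leaves the number where it was. The earlier steps shown here all exchanged one whole ring for another on the carbonyl carbon, so none of them showed what a single added group does at one fixed place on that ring. This step shows that this carbon can carry a methoxy, with its 2 heavy atoms and 1 hydrogen-bond acceptor, without any shift beyond the scatter.

From the compounds shown here alone, whether the same holds for other groups on this carbon, such as a hydroxyl group, a chlorine atom or a longer ether chain, stays open, as does the effect of taking away either of the neighbouring methoxy groups on this ring. Nothing given here bears on why the added methoxy leaves the number within the scatter.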